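Formyl to hydroxymethyl on the fused core

The source may hold more compounds than are shown below. What is called first, only, known or untested is meant among the compounds shown, and "the series" means these compounds.

Of the compounds shown here, three on the shared core have been measured: compound 1 `Cc1ccc2c(Cc3nn4cc(-c5ccc(Br)cc5)nc4s3)coc2c1`, compound 2 `Cc1ccc2c(Cc3nn4c(C=O)c(-c5ccc(Cl)cc5)nc4s3)coc2c1` and compound 3 `Cc1ccc2c(Cc3nn4c(C=O)c(-c5ccc(Br)cc5)nc4s3)coc2c1`. In a functional assay on the whole organism (strain Wistar albino) for inhibition, with Rattus norvegicus as the target, read by paw edema, with a stated time of 1 h, at a dose of 100 mg/kg by the oral route (on this read-out higher numbers stand for more inhibition at the one dose given (going by the name of the read-out) and lower numbers for less inhibition), compound 1 gives 10.3%, compound 2 gives 11.4% and compound 3 gives 12.4%. On these numbers compound 3 is nominally the highest, yet both steps into it, a number 2.1 percentage points higher from compound 1 to compound 3 (within the scatter) and a number 1 percentage points higher from compound 2 to compound 3 (within the scatter), sit inside the scatter, so the three are not separated.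

Compound 4 `Cc1ccc2c(Cc3nn4c(CO)c(-c5ccc(Br)cc5)nc4s3)coc2c1` differs from compound 3 in one place: hydroxymethyl in place of formyl on an aromatic carbon. Within the data shown here, no measured pair covers a formyl turned into hydroxymethyl. Among the measured compounds shown here, the only step touching this carbon is a number 2.1 percentage points higher from compound 1 to compound 3 (within the scatter), formyl in place of hydrogen, which itself stayed within the scatter, and the halogen swap a number 1 percentage points higher from compound 2 to compound 3 (within the scatter) was likewise flat. Nothing in the series therefore points to a move beyond the scatter, and the expected step is a number 0.4 percentage points lower from compound 3 to compound 4 (within the scatter). Compound 4 is estimated at 12% in this assay, with an expected range of 4% to 20%.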

Compound 4, a percentage reported as inhibition, in the whole organism at one dose (the size of the read-out at that dose, not a potency): 7.2%
For compound 4 the middle estimate is 4.8 percentage points above the measured one, within the range that was stated.
By their numbers in this assay, from the lowest: compounds 4, 1, 2 and 3 (each within the scatter of the next).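

Hydroxymethyl on this aromatic carbon, next to the ring nitrogen, gives a number 5.2 percentage points lower from compound 3 to compound 4 (within the scatter) against formyl and a number 3.1 percentage points lower from compound 1 to compound 4 (within the scatter) against hydrogen in this assay on the shared core with the 4-bromophenyl group. Hydrogen, formyl and hydroxymethyl are therefore not separated at this position, and the hydrogen-bond donor that hydroxymethyl brings and formyl lacks does not produce a step beyond the scatter. No available data bear on the reason for these small differences.

From the compounds shown here alone, it remains open whether any group at this carbon can move the read-out beyond the scatter, and a carboxylic acid, an aminomethyl group or a longer chain would test that. Going by these compounds, with every value taken at one dose and one time, a difference at other doses or times also remains open.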